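A Methoxy Group on the Pyrazole of Compound 1

The compounds below may be only part of what the source reports. "The series", "measured", "known", "first", "only" and "open" are said of these compounds alone.

Compound 1 `CCCC(Oc1ccc(-n2cccn2)cc1)c1ccc(C(=O)NCCC(=O)O)cc1` was examined in a functional assay on cells for antagonist activity at Glucagon receptor (Homo sapiens), read by cAMP accumulation, in the presence of a further agent that is not named here; a lower number here means a stronger inhibitor, a higher number a weaker inhibitor. For compound 1 the result is a limit of the assay rather than a number, > 55000 nM, and it is the one case here that sits at the limit of > 55000 nM in this assay, at which 1 of the 3 values shown sits. Going by the values given here, compound 2 `CCCC(Nc1cnc(-n2cc(C(F)(F)F)cn2)nc1)c1ccc(C(=O)NCCC(=O)O)cc1` gives 490 nM in this assay, and compound 3 `CCCC(Nc1ccc(-n2cnc(C(F)(F)F)c2)cc1)c1ccc(C(=O)NCCC(=O)O)cc1` gives 4700 nM; each differs from compound 1 in more than one place, so no single step links them to it. Compound 4 `CCCC(Oc1ccc(-n2cc(OC)cn2)cc1)c1ccc(C(=O)NCCC(=O)O)cc1` differs from compound 1 by methoxy in place of hydrogen on an aromatic carbon. No measured step of this kind exists among these compounds, so the change is expected to be an at least 1.3-fold lower number from compound 1 to compound 4 (0.13 log units; that floor lies within the scatter), likely within the scatter. Compound 4 is therefore estimated at 40000 nM, between 10000 nM and 110000 nM, and may again be reported only as a limit.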

Compound 4, antagonist equilibrium constant: > 23000 nM
Compound 4 gave a limit, no number; the forecaster's own chance of this, stated with the estimate: 55%; the middle value does not contradict the limit.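

Going by these compounds alone, compound 1 and compound 4 are both reported only as limits of the assay, so no step between them can be read. On these data alone, whether methoxy in place of hydrogen on an aromatic carbon changes inhibition at all remains open.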